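A few compounds are considered here, and "the series" means these few. Any claim that something is new, unique, unknown or untested is made for them only; others in the source may bear on it.

Compound 1 `Cc1ccsc1C(c1ccccc1)N1CCN(c2ncnc3c2cnn3-c2ccccc2)CC1`: in a functional assay on cells (Rhabdomyosarcoma cell, Homo sapiens) for cytotoxicity (on this read-out lower numbers stand for stronger inhibition and higher numbers for weaker inhibition), compound 1 gives > 25000 nM, which is a limit of the assay.
Compound 2 `Cc1ccsc1C(c1c(C)noc1C)N1CCN(c2ncnc3c2cnn3-c2ccccc2)CC1`: in this assay compound 2 gives > 25000 nM, again a limit and not a number.

On the numbers shown, compound 1 stands only at a limit, as does every value seen here (the limit of > 25000 nM in this assay, at which 2 of the 2 values shown sit). Among the compounds with values here, the single measured step, a step that the two limits leave unreadable from compound 1 to compound 2, is therefore unreadable. Compound 3 `c1ccc(C(c2nccs2)N2CCN(c3ncnc4c3cnn4-c3ccccc3)CC2)cc1` differs from compound 1 by 1,3-thiazol-2-yl in place of 3-methylthiophen-2-yl on a saturated chain carbon bound to an amine nitrogen in a ring and an aromatic carbon. Within the data shown here, no measured step gives a readable size for such a change, so no shift beyond the scatter is expected, and compound 3 is expected to remain at the limit. The estimate for compound 3 is 30000 nM, ranging from 10000 nM to 100000 nM. This corresponds to an expected step that the limit leaves unreadable from compound 1 to compound 3.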

Compound 3, half-maximal inhibitory concentration: > 25000 nM
Compound 3: no number, only a limit (the forecaster's own chance of this, stated with the estimate: 80%); the middle value does not contradict the limit.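

The step between compound 1 and compound 3 cannot be read, since both stand only at a limit in this assay: the limit of > 25000 nM in this assay, at which 3 of the 3 values shown sit. The compounds shown leave open what actual value compound 1, compound 2 or compound 3 has in this assay, and whether either change shifts it.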